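This account rests on a few compounds, and the source may have more. Where it says the series, first, only, none or still open, it means among the compounds named here.

The series rests on a shared core, drawn without defined configuration in compound 1 `CCOC(=O)C1(C(=O)NCc2ccc(C)cc2)CC1c1cc(OC)c(OC)c(OC)c1` and with defined configuration in compound 3 `CCOC(=O)[C@]1(C(=O)NCc2ccc(C)cc2)C[C@H]1c1cc(OC)c(OC)c(OC)c1`, while compound 2 `COc1cc([C@H]2C[C@@]2(CO)C(=O)NCc2ccc(C)cc2)cc(OC)c1OC` carries a hydroxymethyl where the others carry an ethyl ester. Within the data shown here, in a functional assay on SW480 cells (Homo sapiens) for cytotoxicity, read by MTT assay, with a stated time of 48 h (on this read-out lower numbers stand for stronger inhibition and higher numbers for weaker inhibition), compound 3 gives 36400 nM, the only plain number among the three values shown. In this assay compound 1 gives 29000 nM; > 100000 nM (2 entries), several entries in all (the several entries of compound 1 in this assay, 29000 nM; > 100000 nM (2 entries)). Two of these entries of compound 1 are limits of the assay, not numbers. Compound 2 in this assay reaches only a limit, > 100000 nM. Among the measured compounds shown here, at the place where compound 1 and compound 3 differ, one is drawn with a defined configuration and the other without (the fact that one of compounds 1 and 3 is drawn with a defined configuration and the other without, at the place where they differ); the single number of compound 1 lies within the scatter of the number of compound 3.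

Compound 4 `CCOC(=O)[C@@]1(C(=O)NCc2ccc(C)cc2)C[C@@H]1c1cc(OC)c(OC)c(OC)c1` has not been measured. (the two compounds have the same atoms and bonds and differ only in configuration as drawn: 2 of 2 stereo elements differ (all stereocentres are inverted: mirror images); a stereocentre at a saturated ring carbon is drawn R in compound 3 and S in compound 4; a stereocentre at a saturated ring carbon is drawn S in compound 3 and R in compound 4). For the measured compounds named here, no measured pair shows the effect of such a full inversion, so no step in this assay can be read from the data. Since compound 1, which carries no defined configuration, sits at the limit in two of its three entries (the several entries of compound 1 in this assay, 29000 nM; > 100000 nM (2 entries)), compound 4 is expected to be no stronger than compound 3. The step from compound 3 to compound 4 is estimated as a 1.6-fold higher number from compound 3 to compound 4 (0.22 log units; within the scatter). Compound 4 is expected to give about 60000 nM in this assay, likely between 20000 nM and 150000 nM.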

Compound 4, half-maximal inhibitory concentration: > 100000 nM
Compound 4 gave a limit, no number; the forecaster's own chance of this, stated with the estimate: 45%; middle value at least 1.6-fold (0.22 log units) away from the limit.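

Inverting both stereocentres at the saturated ring carbons, with atoms and bonds unchanged, gives the first readable step of the series in this assay and shows that configuration alone can move this read-out beyond the scatter: (an at least 2.7-fold higher number from compound 3 to compound 4 (0.43 log units; beyond the scatter)). Going by these compounds, compound 4 gives > 100000 nM in this assay and this is a limit and not a number, so the true size of the step stays open on its upper side, and this limit is shared: (the limit of > 100000 nM in this assay, at which 2 of the 4 values shown sit). Compound 1, drawn without defined configuration at this place, can now be set beside two drawn forms, one giving a number and the other only a limit, and its own entries hold both kinds: (the several entries of compound 1 in this assay, 29000 nM; > 100000 nM (2 entries)).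

On these data alone, the step between the ethoxycarbonyl and hydroxymethyl compounds cannot be read, since both ends are limits, and as the two stereocentres change together, the contribution of each alone remains unknown. Also open, as far as these compounds go, is whether a carboxylic acid or a primary amide in place of the ethoxycarbonyl group would keep the same order between the two mirror-image forms.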